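Swapping an Aryl-Chain Amine for an Ethylpiperazine

The compounds below may be only part of what the source reports. "The series", "measured", "known", "first", "only" and "open" are said of these compounds alone.

Measured so far in a functional assay on DLD-1 cells (Homo sapiens) for inhibition, read by MTT assay, with a stated time of 72 h; on this read-out lower numbers stand for stronger inhibition and higher numbers for weaker inhibition:
- compound 1, `CNCc1c(OC)cc(Oc2cccc(Nc3ccccc3)c2)cc1OC`, gives 11900 nM
- compound 2, `COc1ccc(CCCNCc2c(OC)cc(Oc3cccc(Nc4ccccc4)c3)cc2OC)cc1`, gives 2540 nM

Among the compounds with values here, compound 2 has the lowest number of the two in this assay; its nearest neighbour is compound 1, and the one step between them, a 4.7-fold lower number from compound 1 to compound 2 (0.67 log units; beyond the scatter), is the only comparison available. That step replaces a hydrogen on the saturated chain carbon bound to the amine nitrogen with a 2-(4-methoxyphenyl)ethyl group, and it lowered the number.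

Compound 3, `CCN1CCN(Cc2c(OC)cc(Oc3cccc(Nc4ccccc4)c3)cc2OC)CC1`, changes the same region of the shared core in a different way: 4-ethylpiperazin-1-yl in place of (3-(4-methoxyphenyl)propyl)amino on a saturated chain carbon bound to an aromatic carbon. The aryl-bearing chain that accompanied the drop from compound 1 to compound 2 is gone, and a small ring with two nitrogen atoms and no hydrogen-bond donor stands in its place. Within the data shown here, no measured step covers this kind of exchange, so the step from compound 1 to compound 2 is only a loose guide: it suggests that a short amine substituent goes with a higher number than a long aryl-bearing one. The number for compound 3 is therefore expected to move back up, as a 3.1-fold higher number from compound 2 to compound 3 (0.50 log units; beyond the scatter), though the ring may not behave like a bare methylamine. The estimate for compound 3 in this assay is 8000 nM, with a range from 2500 nM to 25000 nM.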

Compound 3, half-maximal inhibitory concentration: > 20000 nM
Compound 3: no number, only a limit; the forecaster's own chance of this, stated with the estimate: 10%; middle value at least 2.5-fold (0.39 log units) away from the limit.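

In this assay compound 3 gives > 20000 nM, which is a limit and not a number. Within the data shown here, putting 4-ethylpiperazin-1-yl in place of (3-(4-methoxyphenyl)propyl)amino on this saturated chain carbon bound to an aromatic carbon gives an at least 7.8-fold higher number from compound 2 to compound 3 (0.89 log units; beyond the scatter), so the number at this one place can go back up as well as down, which the single earlier step could not show. Against the small methylamino group the result is an at least 1.6-fold higher number from compound 1 to compound 3 (0.22 log units; that floor lies within the scatter), and with that floor inside the scatter, compound 3 cannot be ranked against compound 1.

The exchange from compound 2 to compound 3 alters the aromatic ring, the chain and the amine hydrogen all at once, leaving open which of these goes with the lower number of compound 2. A plain propylamino group would test the aromatic ring on its own, while 4-(3-(4-methoxyphenyl)propyl)piperazin-1-yl would keep that ring and chain on a piperazine that has no amine hydrogen.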